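Pyridinylcyanoguanidines: alkyl to aryl on the imine nitrogen

The source may report more compounds than this note shows. Statements on the series, on what has been measured and on what is new or still open speak of the compounds shown alone.

Measured so far:
compound 1 `CCC(CC)/N=C(\NC#N)Nc1ccncc1` – 2.5 mg/kg
compound 2 `CCC(CC)(CC)/N=C(\NC#N)Nc1ccncc1` – 2.5 mg/kg

Both values come from a functional assay on the whole organism (blood, strain Wistar-Okamoto) with Rattus norvegicus as the target, with a stated time of 5 days; on this read-out lower numbers stand for an effect already at smaller amounts and higher numbers for an effect only at larger amounts of compound. Compound 1 stands level with compound 2 at the digits shown; the step of no change at the digits printed from compound 1 to compound 2 (within the scatter) is the only step recorded, and it lies within the scatter. It tells that the substituent on the double-bonded nitrogen accepts added saturated bulk without a shift in the minimum effective dose.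

Compound 3 `N#CN/C(=N\c1ccccc1)Nc1ccncc1` is not yet measured. It differs from compound 1 as follows: phenyl in place of pentan-3-yl on a double-bonded nitrogen. Among the measured compounds shown here, no measured step replaces an alkyl group with an aromatic ring at this nitrogen, so the only guide is the tolerance of that position seen in the step from compound 1 to compound 2. On that basis the step of no change at the digits printed from compound 1 to compound 3 (within the scatter) is expected to stay within the scatter.

Compound 3 is accordingly expected to give 2.5 mg/kg in this assay, with a range from 1 mg/kg to 6 mg/kg.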

Compound 3, minimum effective dose: 50 mg/kg
The estimate for compound 3 lay 20-fold (1.30 log units) below the measured number; measured number above the stated range.
By their numbers in this assay, from the lowest: compounds 1 and 2 (each within the scatter of the next); then compound 3.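

In this assay, among the compounds shown here, the change from pentan-3-yl to phenyl on the double-bonded nitrogen gives a 20-fold higher number from compound 1 to compound 3 (1.30 log units; beyond the scatter), the first step beyond the scatter. The tolerance seen in no change at the digits printed from compound 1 to compound 2 (within the scatter) therefore covers added saturated bulk on this nitrogen but does not carry over to phenyl, so this position is sensitive to the kind of group it holds and not only open to bulk. Nothing at hand bears on the reason for this large step.

A cyclohexyl group on the same nitrogen would show whether the step follows from the aromatic ring or from the loss of the branched saturated chain. A benzyl group, or a phenyl ring carrying a methoxy group or chlorine, would show whether any aromatic substituent here can return to the level of compound 1.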